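Series notes: the step from methyl to methoxy

A few compounds are considered here, and "the series" means these few. Any claim that something is new, unique, unknown or untested is made for them only; others in the source may bear on it.

Values from an ADME assay on HPLF cells (Homo sapiens) for cytotoxicity, with a stated time of 24 h (on this read-out higher numbers stand for lower toxicity in this test and lower numbers for higher toxicity in this test), are as follows
- compound 1 `O=C1/C(=C/c2ccc(F)cc2)CCC/C1=C\c1cccc([N+](=O)[O-])c1` gives 36000 nM
- compound 2 `CN(C)c1ccc(/C=C2\CCC/C(=C\c3cccc([N+](=O)[O-])c3)C2=O)cc1` gives > 400000 nM (a limit)
- compound 3 `Cc1ccc(/C=C2\CCC/C(=C\c3cccc([N+](=O)[O-])c3)C2=O)cc1` gives > 400000 nM (a limit)

Compound 3 reads > 400000 nM in this assay, which is a limit and not a number. Compound 2 and compound 3 share (the limit of > 400000 nM in this assay, at which 2 of the 3 values shown sit).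

The next change is methoxy in place of methyl on an aromatic carbon, para to a large group, which gives compound 4 `COc1ccc(/C=C2\CCC/C(=C\c3cccc([N+](=O)[O-])c3)C2=O)cc1`. The difference is methoxy in place of methyl on an aromatic carbon, or 4-methylphenyl to 4-methoxyphenyl.

Two measured swaps on an aromatic carbon bear on this. Dimethylamino in place of fluoro gives an at least 11-fold higher number from compound 1 to compound 2 (1.04 log units; beyond the scatter), a large step. Methyl in place of fluoro gives an at least 11-fold higher number from compound 1 to compound 3 (1.04 log units; beyond the scatter), also large. The swap of dimethylamino for methyl gives a step that the two limits leave unreadable from compound 2 to compound 3, so it sets no size.

Among these three compounds, only the fluoro compound gives a number. Compound 4 also lacks fluoro, so it is expected to sit with compound 2 and compound 3, with no step beyond the scatter. The estimated change is a number no higher from compound 3 to compound 4 (the limit leaves the size open) in this assay. Compound 4 is expected at 400000 nM, with an estimated range from 150000 nM to 800000 nM, and a report of only a limit is likely.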

Compound 4, half-maximal cytotoxic concentration: 354000 nM
Beside the measured number, compound 4's estimate is 1.1-fold (0.05 log units) above it, and the stated range covers the measured number.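

On the aromatic carbon para to a large group, compound 4 is the first compound without fluoro to give a number rather than a limit in this assay, whereas the dimethylamino and methyl compounds stay at the limit: the limit of > 400000 nM in this assay, at which 2 of the 4 values shown sit.

Methoxy in place of fluoro gives a 9.8-fold higher number from compound 1 to compound 4 (0.99 log units; beyond the scatter), which puts a readable size on a step away from fluoro at this position, where the earlier steps gave only floors. Methoxy in place of methyl gives an at least 1.1-fold lower number from compound 3 to compound 4 (0.05 log units; that floor lies within the scatter), and methoxy in place of dimethylamino gives an at least 1.1-fold lower number from compound 2 to compound 4 (0.05 log units; that floor lies within the scatter); both floors lie within the scatter, so these steps show no separation of methoxy from the other two groups, and the limits leave their true sizes open.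

Fluoro remains the only halogen shown, so it is open whether chloro, or a carboxylic acid, would sit with compound 1 or with compound 4. On these data alone, the nitro group is the same in all four compounds, so it is also open whether the step from fluoro to methoxy keeps its size with an amine in place of nitro.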